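Dipropylamino to diisopropylamino: notes on compound 3

The source may hold more compounds than are shown below. What is called first, only, known or untested is meant among the compounds shown, and "the series" means these compounds.

Values in a functional assay on MCF7 cells (Homo sapiens) for antiproliferative activity; on this read-out lower numbers stand for stronger inhibition and higher numbers for weaker inhibition:
- Compound 1 `CC(C)=CCc1cc(C(=O)Nc2cc3ccc(OCC4CCN(C)C4)c(C)c3oc2=O)ccc1O`: 1550 nM
- Compound 2 `CCCN(CCC)CCCOc1ccc2cc(NC(=O)c3ccc(O)c(CC=C(C)C)c3)c(=O)oc2c1C`: > 50000 nM
- Compound 3 `CC(C)=CCc1cc(C(=O)Nc2cc3ccc(OCCCN(C(C)C)C(C)C)c(C)c3oc2=O)ccc1O`: not yet measured

The value of compound 2, > 50000 nM, is a limit of the assay and not a number. Compound 2 therefore stands at the limit of > 50000 nM in this assay, at which 1 of the 2 values shown sits.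

Compound 3 is an isomer of compound 2: diisopropylamino in place of dipropylamino on a saturated chain carbon, three bonds along the chain from an oxygen on an aromatic ring. The change is diisopropylamino in place of dipropylamino on a saturated chain carbon, three bonds along the chain from an oxygen on an aromatic ring.

Among the compounds with values here, one measured step bears on this, an at least 32-fold higher number from compound 1 to compound 2 (1.50 log units; beyond the scatter). It is large and shows that a change in this side chain can move the read-out strongly. Within the data shown here, no measured step makes this exact swap, and compound 2 offers only a limit. Compound 3 is therefore expected to remain weak in this assay, with any move towards lower numbers being modest.

The expected step is an at least 1.6-fold lower number from compound 2 to compound 3 (0.22 log units; that floor lies within the scatter).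

The estimate for compound 3 is 30000 nM, with an expected range of 4000 nM to 100000 nM.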

Compound 3, half-maximal inhibitory concentration: 1310 nM
Estimate against measurement, compound 3: 23-fold (1.36 log units) above; measured number below the stated range.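

In this assay the swap of dipropylamino for diisopropylamino, with the same atoms joined differently, gives an at least 38-fold lower number from compound 2 to compound 3 (1.58 log units; beyond the scatter). From the compounds shown here alone, compound 2 remains a limit of the assay and not a number, so the full size of this step stays unknown: the limit of > 50000 nM in this assay, at which 1 of the 3 values shown sits. The second reading is a 1.2-fold lower number from compound 1 to compound 3 (0.07 log units; within the scatter), so at this place a side chain with no ring, ending in diisopropylamino, matches the ring-bearing side chain of the earlier compound.

The compounds shown do not tell why two amines of identical atom content part so sharply in this assay. Open too, going by these compounds, is how a piperidine or a morpholine would read in place of diisopropylamino, or a nitrogen carrying one propyl and one isopropyl.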